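The compounds below may be only part of what the source reports. "The series", "measured", "known", "first", "only" and "open" are said of these compounds alone.

Three compounds share one core. Compound 1 `O=c1cc(-c2ccccc2)oc2cc(OCc3ccccc3)c(OCCCCN3CCCCC3)c(O)c12` carries a benzyl on an oxygen on the aromatic ring and a chain ending in piperidin-1-yl; in a functional assay on A549 cells (Homo sapiens) for antiproliferative activity, read by MTT assay, with a stated time of 48 h (a higher number here means a weaker inhibitor, a lower number a stronger inhibitor), compound 1 gives 1900 nM. Compound 2 `COc1cc2oc(-c3ccccc3)cc(=O)c2c2c1OCCCCO2` lacks that chain altogether; in this assay compound 2 reaches only > 100000 nM, which is a limit of the assay and not a number. Going by the values given here, compound 3 `O=c1cc(-c2ccccc2)oc2cc(O)c(OCCCCN3CCCCC3)c(O)c12` has hydrogen in place of the benzyl; in this assay compound 3 gives 75000 nM, the highest of the two numbers known. Among the compounds with values here, the only measured step is a 39-fold higher number from compound 1 to compound 3 (1.60 log units; beyond the scatter), and it concerns the benzyl end of the molecule.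

Compound 4 `CN1CCN(CCCCOc2c(O)cc3oc(-c4ccccc4)cc(=O)c3c2O)CC1` differs from compound 3 by 4-methylpiperazin-1-yl in place of piperidin-1-yl on a saturated chain carbon, four bonds along the chain from an oxygen on an aromatic ring. Within the data shown here, no measured step touches this end of the chain, so the change is untested here. The expected step is therefore no change at the digits printed from compound 3 to compound 4 (within the scatter), which lies within the scatter. Compound 4 is estimated at 75000 nM, expected to fall between 30000 nM and 150000 nM.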

Compound 4, half-maximal inhibitory concentration: > 100000 nM
Compound 4 ended at the assay's limit (the forecaster's own chance of this, stated with the estimate: 35%); middle value at least 1.3-fold (0.12 log units) away from the limit.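

Going by these compounds alone, this is the first measured change at the far end of the chain, where 4-methylpiperazin-1-yl stands in place of piperidin-1-yl. In this assay compound 4 gives > 100000 nM, which is a limit of the assay and not a number. The step is an at least 1.3-fold higher number from compound 3 to compound 4 (0.12 log units; that floor lies within the scatter), so it gives no sign of a stronger inhibitor, and its full size cannot be read, with the value sitting at the assay's ceiling: the limit of > 100000 nM in this assay, at which 2 of the 4 values shown sit.

From the compounds shown here alone, it remains open how 4-methylpiperazin-1-yl would behave with the benzyl of compound 1 on the oxygen, where the number lies well clear of that limit. Other chain ends, such as morpholin-4-yl or a dimethylamino group, and a longer chain also remain open.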